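The source may hold more compounds than are shown below. What is called first, only, known or untested is meant among the compounds shown, and "the series" means these compounds.

Three compounds have been measured in a functional assay on A498 cells (Homo sapiens) for cytotoxicity; on this read-out higher numbers stand for weaker inhibition of growth and lower numbers for stronger inhibition of growth:
compound 1 `COc1ccc(C2=C(c3ccc(SC)cc3)CC3CCCN3C2=O)cc1Br` gives 600 nM
compound 2 `COc1ccc(C2=C(c3ccc(SC)cc3)CC3CCCN3C2=O)cc1C` gives 400 nM
compound 3 `CSc1ccc(C2=C(c3ccc(F)c(F)c3)C(=O)N3CCCC3C2)cc1` gives 100 nM

Compound 2 stands second highest of the three, nearest to compound 1 and furthest from compound 3. The small swap on the aromatic carbon gave a 1.5-fold lower number from compound 1 to compound 2 (0.18 log units; within the scatter), within the scatter, whereas exchanging the whole aryl ring gave a 4.0-fold lower number from compound 2 to compound 3 (0.60 log units; beyond the scatter) and a 6.0-fold lower number from compound 1 to compound 3 (0.78 log units; beyond the scatter), both modest steps beyond it. Compound 4 `COc1ccc(C2=C(c3ccc(SC)cc3)CC3CCCN3C2=O)cc1OC` differs from compound 2 in one place: methoxy in place of methyl on an aromatic carbon. Among the measured compounds shown here, no measured step swaps a methoxy for a methyl; the only comparable change, the single-group swap on the same aromatic carbon from compound 1 to compound 2, stayed within the scatter, and the ring exchanges to compound 3 do not bear on it. A small step, or none beyond the scatter, is therefore expected: a 1.1-fold higher number from compound 2 to compound 4 (0.05 log units; within the scatter). Compound 4 is estimated at 450 nM, within 200 nM to 1000 nM.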

Compound 4, concentration for 50% growth inhibition: 8000 nM
For compound 4 the middle estimate is 18-fold (1.25 log units) below the measured one, outside the stated range (above it).
By their numbers in this assay, from the lowest: compound 3; then compounds 2 and 1 (each within the scatter of the next); then compound 4.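

This aromatic carbon, ortho to a methoxy group, is not indifferent to what it carries: bromo and methyl lie within the scatter of each other, yet methoxy gives a 20-fold higher number from compound 2 to compound 4 (1.30 log units; beyond the scatter) and a 13-fold higher number from compound 1 to compound 4 (1.12 log units; beyond the scatter). So growth inhibition falls sharply with this one small change, which adds a single oxygen and a hydrogen-bond acceptor to methyl. Nothing available explains why the number rises so much.

Open, as far as these compounds go, is whether the oxygen itself matters. A hydroxyl or an ethyl on this carbon could separate the oxygen from the chain length, depending on whether each stays with methyl and bromo or falls with methoxy.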